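Replacing the carboxylic acid chain with a methylsulfonyl group

A few compounds are considered here, and "the series" means these few. Any claim that something is new, unique, unknown or untested is made for them only; others in the source may bear on it.

Measured compounds in an assay on cells for binding affinity to vitamin D3 receptor (Homo sapiens), read by fluorescence, tested at 1 uM; on this read-out higher numbers stand for more inhibition at the one concentration tested (going by the name of the read-out) and lower numbers for less inhibition:
- compound 1, `CCC(CC)(c1ccc(OCC(=O)O)c(C)c1)c1ccc(OCC(O)C(C)(C)C)c(OCC(O)C(C)(C)C)c1`, gives 10%
- compound 2, `CCC(CC)(c1ccc(OCCCCC(=O)O)c(C)c1)c1ccc(OCC(O)C(C)(C)C)c(OCC(O)C(C)(C)C)c1`, gives "not active" (no number reported)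
- compound 3, `CCC(CC)(c1ccc(OCCCCCC(=O)O)c(C)c1)c1ccc(OCC(O)C(C)(C)C)c(OCC(O)C(C)(C)C)c1`, gives "not active" (no number reported)

All three share the same core and differ only in the acid-bearing chain on one aromatic oxygen. Compound 1 shows a small inhibition in this assay. For compound 2 and compound 3 no number was reported; each is recorded only as not active, so compound 3 stands without a numerical value and cannot be ranked against compound 1 beyond the statement that neither shows meaningful inhibition.

Compound 4, `CCC(CC)(c1ccc(OS(C)(=O)=O)c(C)c1)c1ccc(OCC(O)C(C)(C)C)c(OCC(O)C(C)(C)C)c1`, is the next compound. Relative to compound 3 the change is methylsulfonyl in place of 5-carboxypentyl on an oxygen on an aromatic ring. Within the data shown here, with no measured step available for this change, the expected step is none beyond the scatter of this assay, since the whole measured set sits at or near inactivity. Compound 4 is therefore expected to give 5%, within a range of 0% to 20%, with a real chance that it is again reported only as not active.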

Compound 4, a percentage reported as inhibition, at one concentration (the size of the read-out at that concentration, not a potency): "not active" (no number reported)
Nothing numeric was reported for compound 4; there is nothing to compare the estimate with.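

In this assay compound 3 and compound 4 are both recorded only as not active, so no step can be read between them, and no evidence shown bears on this result. The compounds shown leave open whether any replacement of this chain on the shared core gives clear inhibition.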